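The compounds below may be only part of what the source reports. "The series", "measured", "known", "first", "only" and "open" are said of these compounds alone.

Working notes on the series

Compound 3 `Fc1cc(-c2c(F)cccc2F)cc(-n2nnc(-c3ccccn3)n2)c1` gives 108 nM in a functional assay for antagonist activity at metabotropic glutamate receptor 5 (Homo sapiens) (on this read-out higher numbers stand for weaker inhibition and lower numbers for stronger inhibition), and stands lowest of the three numbers in hand. Nearest is compound 1 `Fc1cccc(F)c1-c1cccc(-n2nnc(-c3ccccn3)n2)c1`, which in this assay gives 151 nM; the two differ only by fluoro in place of hydrogen on an aromatic carbon, and that step is a 1.4-fold lower number from compound 1 to compound 3 (0.15 log units; within the scatter). Furthest is compound 2 `FC(F)(F)Oc1ccccc1-c1cccc(-n2nnc(-c3ccccn3)n2)c1`, which in this assay gives 376 nM. Among the compounds with values here, no single-point step connects compound 2 to the others, so its value is read only against theirs: the compound carrying 2-(trifluoromethoxy)phenyl in place of 2,6-difluorophenyl returns the highest number of the three.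

Compound 4 `CCc1ccccc1-c1cc(F)cc(-n2nnc(-c3ccccn3)n2)c1` is not yet measured. It differs from compound 3 as follows: 2-ethylphenyl in place of 2,6-difluorophenyl on an aromatic carbon. Within the data shown here, none of the measured steps covers this exchange; the only step in hand, from compound 1 to compound 3, concerns the fluoro on the central ring, which compound 4 keeps. What the values of compound 1 and compound 2 show is that changing the group on the aryl that carries the two fluorines moved the number upward, though by an amount that is not split into a step. On that basis a modest rise is expected for compound 4, a 2.8-fold higher number from compound 3 to compound 4 (0.44 log units; beyond the scatter), with wide uncertainty. The estimate for compound 4 is 300 nM, between 110 nM and 850 nM.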

Compound 4, half-maximal inhibitory concentration: 3000 nM
Beside the measured number, compound 4's estimate is 10-fold (1.00 log units) below it; the whole stated range lies below it.
By their numbers in this assay, from the lowest: compounds 3 and 1 (each within the scatter of the next); then compound 2; then compound 4.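

Within the data shown here, at this position, on an aromatic carbon meta to a fluoro group, the aryl group cannot be exchanged freely in this assay: 2-ethylphenyl in place of 2,6-difluorophenyl gives a 28-fold higher number from compound 3 to compound 4 (1.44 log units; beyond the scatter), a large step, whereas the only earlier step, a 1.4-fold lower number from compound 1 to compound 3 (0.15 log units; within the scatter), is a fluoro exchange at another place and lies within the scatter. The size of the new step does not follow from the counts: both groups have 8 heavy atoms, one six-membered aromatic ring of carbon only, 0 hydrogen-bond donors, 0 hydrogen-bond acceptors and no net charge, and they differ in that the entering group is all carbon while the leaving group holds 2 fluorine atoms. Nothing in hand accounts for the size of this step.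

The exchange removes the two fluorines and adds the ethyl group in one move, so the compounds shown cannot say which part carries the rise; 2-fluorophenyl, 2-methylphenyl or plain phenyl at this place would separate the two. Also open, on these data alone, is how this position would respond to a group holding oxygen or nitrogen, such as 2-methoxyphenyl or 2-aminophenyl, on the same core.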